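From Hexyl to 4-Fluorobenzyl in a Small Series

The source may hold more compounds than are shown below. What is called first, only, known or untested is meant among the compounds shown, and "the series" means these compounds.

In a functional assay on a cell-free system (Platelet, plasma, Homo sapiens) for inhibition (on this read-out lower numbers stand for stronger inhibition and higher numbers for weaker inhibition), compound 1 `COc1ccc(NC(=O)C2CCCNC2)cc1` gives 983000 nM, compound 2 `CCCCCCOc1ccc(NC(=O)C2CCCNC2)cc1` gives 75000 nM and compound 3 `O=C(Nc1cccc(OCc2ccccc2)c1)C1CCCNC1` gives 128000 nM. Compound 2 thus lies well under compound 1 and within the scatter of compound 3. Compound 4 `O=C(Nc1ccc(OCc2ccc(F)cc2)cc1)C1CCCNC1` departs from compound 2 by 4-fluorophenyl in place of pentyl on a saturated chain carbon bound to an oxygen on an aromatic ring, with 4-fluorophenyl in place of pentyl on a saturated chain carbon bound to an oxygen on an aromatic ring. Within the data shown here, the one measured step at this place, a 13-fold lower number from compound 1 to compound 2 (1.12 log units; beyond the scatter), was large, but it brought the pentyl in rather than exchanging it. Compound 3, with a phenyl on such a carbon, gives 128000 nM. No step beyond the scatter is therefore expected in this assay, and the estimated step is a 1.1-fold higher number from compound 2 to compound 4 (0.03 log units; within the scatter). For compound 4 the estimated value is 80000 nM, with an expected range from 25000 nM to 250000 nM.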

Compound 4, half-maximal inhibitory concentration: 116000 nM
Compound 4: middle estimate off by 1.5-fold (0.16 log units), on the low side, within the range that was stated.
By their numbers in this assay, from the lowest: compounds 2, 4 and 3 (each within the scatter of the next); then compound 1.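

In this assay the exchange of pentyl for 4-fluorophenyl on a saturated chain carbon bound to an oxygen on an aromatic ring gives a 1.5-fold higher number from compound 2 to compound 4 (0.19 log units; within the scatter), so here an aromatic ring and an open chain cannot be told apart. The gain over compound 1 persists with the ring, at an 8.5-fold lower number from compound 1 to compound 4 (0.93 log units; beyond the scatter), and so does not depend on the hexyl chain alone. No evidence bears on why the two groups read alike.

On these data alone, an amine or a carboxylic acid at the end of this chain, or a chain longer than hexyl, remains open. So does whether the fluorine in 4-fluorobenzyl counts for anything.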